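Chain Extension on the Amide in Two Aniline Variants

This account rests on a few compounds, and the source may have more. Where it says the series, first, only, none or still open, it means among the compounds named here.

Compound 1 `C/C=C/C(=O)Nc1cccc(Oc2nc(Nc3cccc(C#N)c3)nc3c2CSCC3)c1` gives 21400 nM in a functional assay on MCF7 cells (Homo sapiens) for antiproliferative activity, read by MTT assay, with a stated time of 72 h; on this read-out lower numbers stand for stronger inhibition and higher numbers for weaker inhibition. Compound 2 `CC/C=C/C(=O)Nc1cccc(Oc2nc(Nc3cccc(C#N)c3)nc3c2CSCC3)c1` differs from it by methyl in place of hydrogen on a saturated chain carbon bound to a double-bonded chain carbon and gives 15900 nM, so that a 1.3-fold lower number from compound 1 to compound 2 (0.13 log units; within the scatter). Compound 3 `C/C=C/C(=O)Nc1cccc(Oc2nc(Nc3ccc(OC)cc3)nc3c2CSCC3)c1` shares the core of compound 1 but carries 4-methoxyphenyl in place of 3-cyanophenyl on a nitrogen on an aromatic ring; compound 3 gives 24300 nM, with a 1.1-fold higher number from compound 1 to compound 3 (0.06 log units; within the scatter). Compound 4 `CC/C=C/C(=O)Nc1cccc(Oc2nc(Nc3ccc(OC)cc3)nc3c2CSCC3)c1` has not yet been measured; it differs from compound 3 by methyl in place of hydrogen on a saturated chain carbon bound to a double-bonded chain carbon, the same change as that made from compound 1 to compound 2, at the same place. Because a 1.3-fold lower number from compound 1 to compound 2 (0.13 log units; within the scatter) stayed within the scatter, compound 4 is expected to show only a 1.3-fold lower number from compound 3 to compound 4 (0.11 log units; within the scatter). In this assay compound 4 is therefore estimated at 18700 nM, with a likely range from 9000 nM to 40000 nM.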

Compound 4, half-maximal inhibitory concentration: 31400 nM
Estimate against measurement, compound 4: 1.7-fold (0.23 log units) below, within the range that was stated.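

The methyl step on the core carrying 4-methoxyphenyl reads a 1.3-fold higher number from compound 3 to compound 4 (0.11 log units; within the scatter), and it does not separate from its counterpart on the core carrying 3-cyanophenyl: the same change on two cores in this assay, a 1.3-fold lower number (0.13 log units; within the scatter) from compound 1 to compound 2 and a 1.3-fold higher number (0.11 log units; within the scatter) from compound 3 to compound 4, 1.7-fold (0.24 log units) apart, within the scatter of two such steps. The change from 3-cyanophenyl to 4-methoxyphenyl, made on the but-1-en-1-yl amide, reads a 2.0-fold higher number from compound 2 to compound 4 (0.30 log units; within the scatter), and it likewise does not separate from the earlier step: the same change on two cores in this assay, a 1.1-fold higher number (0.06 log units; within the scatter) from compound 1 to compound 3 and a 2.0-fold higher number (0.30 log units; within the scatter) from compound 2 to compound 4, 1.7-fold (0.24 log units) apart, within the scatter of two such steps. Both changes therefore carry from one core to the other in this assay without a detectable difference, yet every step lies within the scatter, so the four compounds show neither that either change has a real effect nor that the two methyl steps truly differ.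

On these data alone, it remains open whether a longer chain on the amide, or an amine at the end of that chain, would move the number beyond the scatter. The same question stands for a carboxylic acid on the aniline ring.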